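This account rests on a few compounds, and the source may have more. Where it says the series, first, only, none or still open, it means among the compounds named here.

Working notes on the series.

Compound 2 `CC(C)C[C@H](N)c1cc(C(F)(F)F)ccc1N1CCN(C(=O)CNc2ccccc2)CC1` is the reference point. Among the measured compounds shown here, in an assay on HEK293 cells for displacement of a labelled ligand from Melanocortin receptor 4 (Homo sapiens) (on this read-out lower numbers stand for stronger inhibition and higher numbers for weaker inhibition), compound 2 gives 3600 nM, the only numeric value in the set. Compound 1 `CC(C)C[C@H](N)c1cc(C(F)(F)F)ccc1N1CCN(C(=O)CCC(N)=O)CC1` sits at a limit of this assay: in this assay compound 1 gives > 10000 nM, which is a limit and not a number (the limit of > 10000 nM in this assay, at which 1 of the 2 values shown sits). For the measured compounds named here, the one measured step, an at least 2.7-fold lower number from compound 1 to compound 2 (0.44 log units; beyond the scatter), shows that placing an aromatic-ring-bearing group on the saturated chain carbon bound to the carbonyl carbon moves the series off the limit.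

Compound 3 `CC(C)C[C@H](N)c1cc(C(F)(F)F)ccc1N1CCN(C(=O)CSc2ccc(Cl)cc2Cl)CC1` is not yet measured. It differs from compound 2 by (2,4-dichlorophenyl)sulfanyl in place of anilino on a saturated chain carbon bound to a carbonyl carbon. The measured step from compound 1 to compound 2 bears on it only indirectly: it shows that an aromatic substituent at this position is tolerated and read as an improvement, but it says nothing about exchanging one aromatic group for another. Going by the values given here, with no direct precedent, the expected step of a 2.0-fold lower number from compound 2 to compound 3 (0.30 log units; within the scatter) is kept small and slightly favourable, with a wide range. For compound 3 the estimate in this assay is 1800 nM, within 400 nM to 8000 nM.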

Compound 3, inhibition constant: 1500 nM
Compound 3: middle estimate off by 1.2-fold (0.08 log units), on the high side; the measured number falls inside the stated range.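

On the saturated chain carbon bound to a carbonyl carbon, the identity of the aromatic-ring-bearing group matters in this assay, not only its presence: (2,4-dichlorophenyl)sulfanyl in place of anilino gives a 2.4-fold lower number from compound 2 to compound 3 (0.38 log units; beyond the scatter) and so takes the series a modest step further. The entering group has 0 hydrogen-bond donors where anilino has 1, so a donor in this group is not needed to reach the level of compound 2, and the overall change relative to carbamoylmethyl is an at least 6.6-fold lower number from compound 1 to compound 3 (0.82 log units; beyond the scatter) in the same assay. That last step is only a bound, as compound 1 stands at a limit and not at a number: the limit of > 10000 nM in this assay, at which 1 of the 3 values shown sits.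

The exchange alters the linking atom and adds two chlorine atoms at once, so the share of each remains unresolved; phenylsulfanyl without chlorine or 2,4-dichloroanilino would separate the two. Also open, from the compounds shown here alone, is how the read-out responds to an ether oxygen in place of the sulfur, to a longer chain carrying the ring, or to an amine or a carboxylic acid on that ring.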